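The source may report more compounds than this note shows. Statements on the series, on what has been measured and on what is new or still open speak of the compounds shown alone.

Working notes on the series, read out in a physicochemical assay for solubility, in phosphate buffer, at pH 6.5; on this read-out lower numbers stand for lower solubility and higher numbers for higher solubility. Compound 1 `CC(C)(C)c1ccccc1Oc1ncccc1NC(=O)Nc1ccc(-c2ccccc2CO)cc1F` gives 2 ug/mL, compound 2 `CN(C)Cc1cccc(-c2ccc(NC(=O)Nc3cccnc3Oc3ccccc3C(C)(C)C)c(F)c2)c1` gives 17 ug/mL, and compound 3 `CC(C)(C)c1ccccc1Oc1ncccc1NC(=O)Nc1ccc(OCC2CCN(Cc3ccccc3)CC2)cc1F` gives 2 ug/mL. Compound 3 therefore stands level with compound 1, the two together holding the lowest of the three numbers, and compound 2 lies clear of both.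

Compound 4 `CC(C)N1CCC(COc2ccc(NC(=O)Nc3cccnc3Oc3ccccc3C(C)(C)C)c(F)c2)CC1` is the next entry, with isopropyl in place of benzyl on an amine nitrogen in a ring. Going by the values given here, no measured pair changes this group, so the evidence is indirect. Among the compounds with values here, the only measured step is an 8.5-fold higher number from compound 1 to compound 2 (0.93 log units; beyond the scatter), which is modest, beyond the scatter, and made at a different place: 3-((dimethylamino)methyl)phenyl in place of 2-(hydroxymethyl)phenyl on an aromatic carbon. It shows that this read-out can move within the series, but it does not transfer directly. Compound 3 already carries the amine nitrogen in a ring and gives only 2 ug/mL, which argues against expecting a large move. A small upward step is expected, smaller than the measured one and possibly within the scatter, though the direction has thin support.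

The expected change is a 3.0-fold higher number from compound 3 to compound 4 (0.48 log units; beyond the scatter). The estimate for compound 4 is 6 ug/mL, with an expected range of 2 ug/mL to 20 ug/mL.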

Compound 4, solubility: 232 ug/mL
Compound 4: middle estimate off by 39-fold (1.59 log units), on the low side, and the stated range ends below it.
By their numbers in this assay, from the lowest: compounds 1 and 3 (each within the scatter of the next); then compound 2; then compound 4.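

In this assay, the group on the amine nitrogen in a ring matters far more than compound 3 alone suggested: isopropyl in place of benzyl gives a 120-fold higher number from compound 3 to compound 4 (2.06 log units; beyond the scatter), so carrying that ring nitrogen does not by itself settle the number. The (1-isopropylpiperidin-4-yl)methoxy group also outdoes both other groups on the aromatic carbon, with a 14-fold higher number from compound 2 to compound 4 (1.14 log units; beyond the scatter) and a 120-fold higher number from compound 1 to compound 4 (2.06 log units; beyond the scatter), which leaves compound 4 with the highest number of the four, each gap beyond the scatter. Between compound 3 and compound 4, the computed counts show no change in hydrogen-bond donors, hydrogen-bond acceptors or net charge; the swap takes out the six-membered aromatic ring of carbon only and goes from 7 heavy atoms to 3.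

No measurement at hand bears on what lies behind this step. As far as these compounds go, it also stays open whether the rise follows the loss of the aromatic ring or belongs to isopropyl itself, and a cyclohexyl or a methyl on the same nitrogen would help separate the two.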